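The source may report more compounds than this note shows. Statements on the series, on what has been measured and on what is new or still open speak of the compounds shown alone.

Measured so far:
compound 1 `CC(C)NC(=O)/C=C1\CCc2ccc(F)cc21` — a functional assay on the whole organism with Mus musculus as the target, in the rotarod test; on this read-out higher numbers stand for an effect only at larger amounts of compound and lower numbers for an effect already at smaller amounts: > 100 mg/kg
compound 2 `Cc1cccc2c1/C(=C/C(N)=O)CC2` — in this assay compound 2 gives 56 mg/kg.

Compound 1 gives > 100 mg/kg, which is a limit of the assay and not a number (the limit of > 100 mg/kg in this assay, at which 1 of the 2 values shown sits). Compound 2 gives 56 mg/kg in this assay. Compound 3 `O=C(/C=C1\CCc2ccc(F)cc21)NC1CC1` differs from compound 1 by cyclopropyl in place of isopropyl on an amide-type nitrogen. Among the compounds with values here, no step between two measured compounds is available here, so its size cannot be read from the data. The step from compound 1 to compound 3 is expected to stay within the scatter, a number no higher from compound 1 to compound 3 (the limit leaves the size open). Compound 3 is therefore expected to give about 100 mg/kg, between 40 mg/kg and 250 mg/kg, quite possibly again only as a limit.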

Compound 3, dose for half-maximal effect: 62 mg/kg
Compound 3: middle estimate off by 1.6-fold (0.21 log units), on the high side; the measured number falls inside the stated range.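

Within the data shown here, with cyclopropyl in place of isopropyl on an amide-type nitrogen, this assay now gives a number at this position rather than a limit, and the first step that can be read here is an at least 1.6-fold lower number from compound 1 to compound 3 (0.20 log units; that floor lies within the scatter) and so need not exceed the usual scatter. Its true size may be larger, as the value of compound 1 is a limit of the assay: the limit of > 100 mg/kg in this assay, at which 1 of the 3 values shown sits. From the compounds shown here alone, what cyclobutyl, a longer chain such as n-butyl, or a hydroxyethyl group on this nitrogen would give remains open.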